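Phenoxy replaces trifluoromethoxy on the aryl of compound 2

The compounds below may be only part of what the source reports. "The series", "measured", "known", "first", "only" and "open" are said of these compounds alone.

For the measured compounds named here, compound 2 `O=C(O)/C=C/c1ccc2noc(-c3ccc(OC(F)(F)F)cc3)c2c1` gives 8370 nM in an assay for inhibition of inositol hexakisphosphate kinase 3 (Homo sapiens), read by colorimetric assay, coupled enzyme assay and malachite green, with a stated time of 120 min, in the presence of a further agent that is not named here (a lower number here means a stronger inhibitor, a higher number a weaker inhibitor), the lowest of the two numbers measured so far, while compound 1 `Cc1ccc(-c2onc3ccc(/C=C/C(=O)O)cc23)cc1` gives 11500 nM; the one measured step, a 1.4-fold lower number from compound 1 to compound 2 (0.14 log units; within the scatter), put trifluoromethoxy in place of methyl on an aromatic carbon. Compound 3 `O=C(O)/C=C/c1ccc2noc(-c3ccc(Oc4ccccc4)cc3)c2c1` carries phenyl in place of trifluoromethyl on an oxygen on an aromatic ring. Going by the values given here, only that single step bears on this new change, and it stayed within the scatter, so no step beyond the scatter in this assay is expected, in either direction. For compound 3 the estimated value is 6000 nM, between 2000 nM and 20000 nM. That estimate means an expected step of a 1.4-fold lower number from compound 2 to compound 3 (0.14 log units; within the scatter).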

Compound 3, half-maximal inhibitory concentration: 760 nM
Compound 3: middle estimate off by 7.9-fold (0.90 log units), on the high side, outside the stated range (below it).
By their numbers in this assay, from the lowest: compound 3; then compounds 2 and 1 (each within the scatter of the next).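

Phenoxy brings an 11-fold lower number from compound 2 to compound 3 (1.04 log units; beyond the scatter) and a 15-fold lower number from compound 1 to compound 3 (1.18 log units; beyond the scatter) in this assay and so shows that this substituent on the aryl can move the number well beyond the scatter, which the change from methyl to trifluoromethoxy did not do. Among these three compounds, only the group carrying a six-membered aromatic ring stands apart. Nothing available explains why phenyl on this oxygen has such an effect.

Still open, as far as these compounds go, is whether the aromatic ring itself matters or merely the added heavy atoms; a cyclohexyl group on that oxygen would separate the two. From the compounds shown here alone, whether a benzyl group or a substituted phenyl would go further also remains open.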